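The source may hold more compounds than are shown below. What is called first, only, known or untested is meant among the compounds shown, and "the series" means these compounds.

Measured compounds in this set:

compound 1, `C[C@@H](O)[C@H](NC(=O)CN(c1nc(Cl)nc2[nH]cnc12)C1CC1)C(=O)O`: 37.6%
compound 2, `NCCCC[C@H](NC(=O)CN(c1nc(Cl)nc2[nH]cnc12)C1CC1)C(=O)OCc1ccccc1`: 16.8%
compound 3, `CC(C)[C@H](NC(=O)CN(c1ncnc2c1ncn2C1CCCCO1)C1CC1)C(=O)OCc1ccccc1`: 25.8%

All three were tested in a functional assay on the whole organism (Tail, strain ICR) with Mus musculus as the target, in the tail flick test, with a stated time of 120 min, at a dose of 25 umol/kg by the oral route; on this read-out lower numbers stand for a weaker effect and higher numbers for a stronger effect at the one dose given. Compound 2 has the lowest of the three numbers, but the gap to compound 3 lies within the scatter of the method, so the two cannot be told apart; only compound 1, whose gap to compound 2 lies beyond the scatter, stands clearly above compound 2 in this assay.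

Compound 4, `O=C(CN(c1nc(Cl)nc2[nH]cnc12)C1CC1)N[C@@H](CCC(=O)OCc1ccccc1)C(=O)OCc1ccccc1`, has not yet been measured. It differs from compound 2 in one place: benzyloxycarbonyl in place of 2-aminoethyl on a saturated chain carbon, three bonds along the chain from an amide-type nitrogen and a carbonyl carbon. For the measured compounds named here, no pair of measured compounds shows this change, so the data give no direct step to lean on. Since the whole measured range is narrow and nothing points to a direction, no step beyond the scatter is expected; the estimated step of a number 5.2 percentage points higher from compound 2 to compound 4 (within the scatter) is expected to be small and upward at most. Compound 4 is therefore expected to give about 22% in this assay, estimated to fall between 8% and 40%.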

Compound 4, a percentage reported as activity, at one dose (the size of the read-out at that dose, not a potency): 45.9%
Estimate against measurement, compound 4: 23.9 percentage points below; the measured number lies above the stated range.
By their numbers in this assay, from the lowest: compounds 2 and 3 (each within the scatter of the next); then compounds 1 and 4 (each within the scatter of the next).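

In this assay, putting benzyloxycarbonyl in place of 2-aminoethyl on a saturated chain carbon, three bonds along the chain from an amide-type nitrogen and a carbonyl carbon, gives a number 29.1 percentage points higher from compound 2 to compound 4 (beyond the scatter). For the compounds shown here, the earlier compounds held no pair differing in one place, so this is the first sign that the number in this assay responds to what this position carries, and the change moves it upward. No measurement is available that explains the step.

The compounds shown do not separate the loss of the amine from the gain of the benzyl ester, since both come in one change. As far as these compounds go, it remains open whether a free carboxylic acid, a methyl ester or a simple hexyl chain at this place would give a similar number.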